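This account rests on a few compounds, and the source may have more. Where it says the series, first, only, none or still open, it means among the compounds named here.

Measured so far in a physicochemical assay for lipophilicity, using the shake flask method; a higher number here means a more lipophilic compound, a lower number a more polar compound:
compound 1, `Nc1ncnc(Oc2ccc(NC(=O)C3(C(=O)Nc4ccc(F)cc4)CC3)cc2F)c1/C=N/O`, gives 2.62.
compound 2, `Nc1ncnc(Oc2ccc(NC(=O)C3(C(=O)Nc4ccc(F)cc4)CC3)cc2F)c1/C=N/OCC(=O)N1CCOCC1`, gives 2.1.
compound 3, `CNc1ncnc(Oc2ccc(NC(=O)C3(C(=O)Nc4ccc(F)cc4)CC3)cc2F)c1/C=N/OC`, gives 3.52.

Compound 2 stands lowest of the three in this assay; compound 1 is nearest and compound 3 furthest, both gaps beyond the scatter. Compound 4, `Nc1ncnc(Oc2ccc(NC(=O)C3(C(=O)Nc4ccc(F)cc4)CC3)cc2F)c1/C=N/OCc1ccccc1`, is not yet measured. It differs from compound 2 in one place: phenyl in place of (morpholin-4-yl)carbonyl on a saturated chain carbon bound to an oxygen. Among the compounds with values here, two measured steps bear on this change. The step of a number 0.52 log units lower from compound 1 to compound 2 (beyond the scatter) shows how much the reading fell when ((morpholin-4-yl)carbonyl)methyl was placed on an oxygen; taking that group away again should recover roughly this amount. The step of a number 0.90 log units higher from compound 1 to compound 3 (beyond the scatter) shows how far the reading rose when only two carbons were added across the core; the benzyl group of compound 4 brings a whole phenyl ring in one piece, so a rise of at least that order, and probably more, is expected on top of the recovered amount. For compound 4 a step of a number 1.90 log units higher from compound 2 to compound 4 (beyond the scatter) is therefore expected, well beyond the scatter and upward. Compound 4 is estimated at 4, with a range of 3.4 to 4.6.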

Compound 4, partition coefficient: 4.45
Beside the measured number, compound 4's estimate is 0.45 log units below it; the measured number falls inside the stated range.
By their numbers in this assay, from the lowest: compound 2; then compound 1; then compound 3; then compound 4.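

Working notes on the substituent on an oxygen: in this assay, benzyl in place of hydrogen gives a number 1.83 log units higher from compound 1 to compound 4 (beyond the scatter), while ((morpholin-4-yl)carbonyl)methyl on the same oxygen gives a number 0.52 log units lower from compound 1 to compound 2 (beyond the scatter), so replacing this hydrogen can move the reading either way, depending on the group that enters. Phenyl in place of (morpholin-4-yl)carbonyl on a saturated chain carbon bound to an oxygen gives a number 2.35 log units higher from compound 2 to compound 4 (beyond the scatter), so in this pair the entering group has fewer heavy atoms than the leaving one and the number still goes up, which shows that heavy-atom count alone does not set the direction here. Nothing available accounts for the direction or size of these steps.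

Still open, going by these compounds, is how the reading responds to a plain ethyl or a longer alkyl chain on the same oxygen, or to an amine or a carboxylic acid at the end of such a chain. Also open, on these data alone, is whether a fluorophenyl or a pyridyl in place of the phenyl of the benzyl group would keep the number near that of compound 4.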